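Saturating the amide ring: compound 3 to compound 4

The source may report more compounds than this note shows. Statements on the series, on what has been measured and on what is new or still open speak of the compounds shown alone.

Measured in an assay on isolated protein for inhibition of solute carrier family 22 member 12 (Homo sapiens), tested at 3 uM; a higher number here means more inhibition at the concentration tested (going by the name of the read-out), a lower number less inhibition:
compound 1 `N#Cc1cc(C(=O)N2CC=CC2)cc(I)c1O` gives 79%
compound 2 `N#Cc1cc(C(=O)N2CC=CC2)cc(Br)c1O` gives 69%
compound 3 `CC(C)(C)c1cc(C(=O)N2CC=CC2)cc(C#N)c1O` gives 92%

Compound 3 stands highest of the three, with compound 1 nearest and compound 2 furthest; both gaps lie beyond the scatter. The measured steps all change the substituent on the aromatic ring: a number 10 percentage points lower from compound 1 to compound 2 (within the scatter), a number 13 percentage points higher from compound 1 to compound 3 (beyond the scatter), a number 23 percentage points higher from compound 2 to compound 3 (beyond the scatter).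

Compound 4 `CC(C)(C)c1cc(C(=O)N2CCCC2)cc(C#N)c1O` differs from compound 3 only at the amide: a group of 5 heavy atoms (4 carbon, 1 nitrogen; one five-membered non-aromatic ring with 1 hetero atom) in place of a group of 5 heavy atoms (4 carbon, 1 nitrogen; one five-membered non-aromatic ring with 1 hetero atom), on a carbonyl carbon. Among the compounds with values here, none of the measured steps touches this part of the molecule, so no measured step bears directly on the change; the aromatic substituent of compound 3, which gave the highest number, is kept in compound 4.

Within the data shown here, with no direct precedent, the expectation in this assay is a step of a number 5 percentage points lower from compound 3 to compound 4 (within the scatter) that stays within the scatter, if anything slightly downward. Compound 4 is therefore estimated at 87%, in the range 70% to 98%.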

Compound 4, a percentage reported as inhibition, at one concentration (the size of the read-out at that concentration, not a potency): 84%
For compound 4 the middle estimate is 3 percentage points above the measured one; measured number inside the range.
By their numbers in this assay, from the lowest: compounds 2, 1, 4 and 3 (each within the scatter of the next, the first and the last beyond it).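

Within the data shown here, replacing the ring that carries one double bond with pyrrolidin-1-yl, on a carbonyl carbon, is the first change at the amide rather than on the aromatic ring, and in this assay it gives a number 8 percentage points lower from compound 3 to compound 4 (within the scatter) so the two compounds cannot be told apart. With tert-butyl kept on the aromatic ring, the double bond is therefore not required for inhibition at the concentration tested. Nothing available explains why the two numbers stay level.

On these data alone, whether it also holds with iodo or bromo on the aromatic ring remains open, since those groups appear here only with the unsaturated ring. As far as these compounds go, how much change the amide accepts is also open: a piperidin-1-yl ring, a morpholin-4-yl ring or an open-chain dimethylamino group on the carbonyl carbon would test this.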